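This account rests on a few compounds, and the source may have more. Where it says the series, first, only, none or still open, it means among the compounds named here.

Measured compounds:
Compound 1, `O=C(Nc1cccc(-c2oc3cc(-c4ccc(F)cc4)ccc3c(=O)c2O)c1)c1ccccc1F`, in a functional assay on MCF7 cells (Homo sapiens) for antiproliferative activity, read by CCK-8 assay, with a stated time of 72 h; a higher number here means a weaker inhibitor, a lower number a stronger inhibitor: 7570 nM
Compound 2, `Cc1cccc(C(=O)Nc2cccc(-c3oc4cc(-c5ccc(F)cc5)ccc4c(=O)c3O)c2)c1`: 7850 nM
Compound 3, `COc1cc(OC)cc(C(=O)Nc2cccc(-c3oc4cc(-c5ccc(F)cc5)ccc4c(=O)c3O)c2)c1`: 3470 nM

Compound 3 gives the lowest number of the three; the steps of a 2.2-fold lower number from compound 1 to compound 3 (0.34 log units; beyond the scatter) and a 2.3-fold lower number from compound 2 to compound 3 (0.35 log units; beyond the scatter) are both beyond the scatter, while the step of a 1.0-fold higher number from compound 1 to compound 2 (0.02 log units; within the scatter) is within it. Compound 4, `CCCc1ccc(C(=O)Nc2cccc(-c3oc4cc(-c5ccc(F)cc5)ccc4c(=O)c3O)c2)cc1`, differs from compound 3 by 4-propylphenyl in place of 3,5-dimethoxyphenyl on a carbonyl carbon. Compound 4 thus carries, like compounds 1 and 2, an aryl group without methoxy groups, and the two steps that introduced the 3,5-dimethoxyphenyl lowered the number modestly. Reversing toward an unsubstituted-type aryl is therefore expected to raise the number by a modest step, a 2.0-fold higher number from compound 3 to compound 4 (0.29 log units; within the scatter), back toward the values of compounds 1 and 2. Compound 4 is estimated at 6800 nM, with a range of 3000 nM to 15000 nM.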

Compound 4, half-maximal inhibitory concentration: 36800 nM
The estimate for compound 4 lay 5.4-fold (0.73 log units) below the measured number; the measured number lies above the stated range.
By their numbers in this assay, from the lowest: compound 3; then compounds 1 and 2 (each within the scatter of the next); then compound 4.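

Among these compounds, at the aryl group on the carbonyl carbon, this assay now shows more than a modest spread: 4-propylphenyl brings an 11-fold higher number from compound 3 to compound 4 (1.03 log units; beyond the scatter) as the largest step at this position so far. The absence of methoxy groups alone does not set the number, with a 4.7-fold higher number from compound 2 to compound 4 (0.67 log units; beyond the scatter) and a 4.9-fold higher number from compound 1 to compound 4 (0.69 log units; beyond the scatter) both in the same direction. Going by these compounds, whether the propyl chain drives the rise stays open, and an ethyl chain, an amine or a carboxylic acid in its place would test this. No available evidence bears on this result.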